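A few compounds are considered here, and "the series" means these few. Any claim that something is new, unique, unknown or untested is made for them only; others in the source may bear on it.

In a functional assay for inhibition, with Rattus norvegicus as the target (a lower number here means a stronger inhibitor, a higher number a weaker inhibitor), compound 1 `CC(C)C/N=c1\c(O)c(O)\c1=N/Cc1ccc(C#N)cc1` gives 10200 nM. Among the three numbers measured so far, compound 3 `CCC(C)(C)/N=c1\c(O)c(O)\c1=N/Cc1ccc(SC)cc1` with 5600 nM lies within the usual scatter of compound 1, so the two cannot be separated with confidence, whereas compound 2 `CC(/N=c1\c(O)c(O)\c1=N/Cc1ccc(C#N)cc1Cl)C(C)(C)C` gives 180 nM, a far lower number that sits well beyond the scatter and marks a much stronger inhibitor. Compound 4 `C/N=c1\c(O)c(O)\c1=N/Cc1ccc(C#N)cc1` has not yet been measured. It differs from compound 1 in a single place: hydrogen in place of isopropyl on a saturated chain carbon bound to a double-bonded nitrogen, which, cut one bond further out, reads as isobutyl becoming methyl. Among the compounds with values here, no measured pair shows a change of this kind, so its effect cannot be read from the other compounds. The shift is expected to be modest and to point toward a weaker inhibitor, a step of a 2.0-fold higher number from compound 1 to compound 4 (0.29 log units; within the scatter) in this assay. Compound 4 is therefore estimated to give 20000 nM, with a likely range from 7000 nM to 60000 nM.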

Compound 4, half-maximal inhibitory concentration: > 30000 nM
Compound 4 gave a limit, no number (the forecaster's own chance of this, stated with the estimate: 20%); middle value at least 1.5-fold (0.17 log units) away from the limit.
By their numbers in this assay, from the lowest: compound 2; then compounds 3 and 1 (each within the scatter of the next). At a limit, above all of these: compound 4.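

In this assay, compound 4 gives > 30000 nM, which is a limit of the assay and not a number. Cutting isobutyl back to methyl is the first single change at this place that can be read directly, and it moves toward a weaker inhibitor, with an at least 2.9-fold higher number from compound 1 to compound 4 (0.46 log units; beyond the scatter), so the isopropyl part of the chain cannot be removed without a loss in this assay. The full size of this step stays unknown because compound 4 sits at a limit: the limit of > 30000 nM in this assay, at which 1 of the 4 values shown sits.

The compounds shown leave open how the number moves with chains of intermediate size, such as ethyl or propyl, and whether a longer chain or a cyclohexyl ring would give a stronger inhibitor than isobutyl. They also leave open whether an amine or a carboxylic acid on this chain would be tolerated.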